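The source may report more compounds than this note shows. Statements on the series, on what has been measured and on what is new or still open speak of the compounds shown alone.

Compound 3 `Cc1nn(-c2ncnc3nc[nH]c23)c2c1C(C(=O)N(C)c1ccccc1)CC(=O)N2` holds the highest number of the three compounds measured in a functional assay on HEK293 cells for agonist activity at G-protein coupled receptor 39 (Homo sapiens), read by scintillation proximity assay and inositol phosphate accumulation, with a stated time of 75 min; a lower number here means that less compound is needed, a higher number that more compound is needed for the effect: in this assay compound 3 gives 5220 nM, whereas compound 1 `Cc1nn(-c2ncnc3nc[nH]c23)c2c1C(OC1CCCC1)CC(=O)N2` gives 62 nM and compound 2 `Cc1nn(-c2ncnc3nc[nH]c23)c2c1C(OCc1ccccc1C#N)CC(=O)N2` gives 127 nM. The step from the ether of compound 1 was an 84-fold higher number from compound 1 to compound 3 (1.93 log units; beyond the scatter), and that from the ether of compound 2 was a 41-fold higher number from compound 2 to compound 3 (1.61 log units; beyond the scatter); between the two ethers themselves the step was only a 2.0-fold higher number from compound 1 to compound 2 (0.31 log units; beyond the scatter).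

Compound 4 `Cc1nn(-c2ncnc3nc[nH]c23)c2c1C(c1ccc(F)cc1Cl)CC(=O)N2` carries the change (2-chloro-4-fluorophenyl in place of methyl(phenyl)carbamoyl on a saturated ring carbon). Going by the values given here, no measured step tests a directly attached aromatic ring at this carbon, so the expectation rests on the two large steps that set compound 3 apart. Both argue that the methyl(phenyl)carbamoyl is the feature tied to the high number of compound 3, and its removal is therefore expected to bring a large step downward in this assay, though a ring joined straight to the saturated carbon need not reach the numbers of compound 1 or compound 2. Compound 4 is estimated at 350 nM, within 60 nM to 2000 nM, a step of a 15-fold lower number from compound 3 to compound 4 (1.17 log units; beyond the scatter).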

Compound 4, half-maximal effective concentration: 280 nM
Estimate against measurement, compound 4: 1.3-fold (0.10 log units) above, within the range that was stated.
By their numbers in this assay, from the lowest: compound 1; then compound 2; then compound 4; then compound 3.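

In this assay, the 2-chloro-4-fluorophenyl on the saturated ring carbon gives a result that shows an aromatic ring joined straight to this carbon can hold a far lower number than the methyl(phenyl)carbamoyl, with a 19-fold lower number from compound 3 to compound 4 (1.27 log units; beyond the scatter) for a change in which both groups carry one six-membered aromatic ring. The high number of compound 3 is therefore not explained by the mere presence of such a ring at this position. The two ethers keep lower numbers, but by modest steps (a 2.2-fold higher number from compound 2 to compound 4 (0.34 log units; beyond the scatter)) and (a 4.5-fold higher number from compound 1 to compound 4 (0.65 log units; beyond the scatter)), and nothing measured here accounts for these differences.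

The compounds shown leave open what the chlorine and the fluorine each contribute, which a plain phenyl at this carbon would address. They also leave open how an amine or a carboxylic acid would fare at this position.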